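A few compounds are considered here, and "the series" means these few. Any claim that something is new, unique, unknown or untested is made for them only; others in the source may bear on it.

Compound 1 `CCCCCCN(C)CNCC(=O)[C@H](CC(=O)O)NC(=O)C(CC)n1ccnc(NCc2nonc2C)c1=O` carries a long ketone side chain on its shared core. In an assay for inhibition of Caspase-8 (Homo sapiens) (on this read-out lower numbers stand for stronger inhibition and higher numbers for weaker inhibition), compound 1 reaches only the limit of the measurement, > 10000 nM, and no number. Compound 2 `CCCCCCN(C)CNCC(=O)[C@H](CC(=O)O)NC(=O)C(CC)n1cc(CC)nc(NCc2nonc2C)c1=O` differs from it by an ethyl group on an aromatic carbon of the core, and in this assay compound 2 gives 9540 nM. The step of an at least 1.0-fold lower number from compound 1 to compound 2 (0.02 log units; that floor lies within the scatter) cannot be sized properly because one end sits at the limit of > 10000 nM in this assay, at which 1 of the 2 values shown sits. Compound 3 `CCC(C(=O)N[C@H](C=O)CC(=O)O)n1ccnc(NCc2nonc2C)c1=O` changes compound 1 elsewhere: hydrogen in place of (((hexyl(methyl)amino)methyl)amino)methyl on a carbonyl carbon, so the ketone becomes an aldehyde. For the measured compounds named here, no measured step touches this place, so none bears on it directly; the one known step is small and at a different site. The expected outcome for compound 3 is therefore uncertain, and the estimated step of an at least 1.2-fold lower number from compound 1 to compound 3 (0.09 log units; that floor lies within the scatter) is taken as modest. Compound 3 is estimated at 8000 nM in this assay, within a wide range from 800 nM to 50000 nM.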

Compound 3, half-maximal inhibitory concentration: 990 nM
Compound 3: middle estimate off by 8.1-fold (0.91 log units), on the high side; the range from low to high includes it.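

Hydrogen in place of (((hexyl(methyl)amino)methyl)amino)methyl on a carbonyl carbon, which turns the ketone into an aldehyde, gives an at least 10-fold lower number from compound 1 to compound 3 (1.00 log units; beyond the scatter) in this assay. For the compounds shown here, this is the first measured sign that the group on this carbonyl carbon can shift the read-out, as the earlier step touched only an aromatic carbon of the core. The step has a floor and no exact size because one of its ends is a limit: the limit of > 10000 nM in this assay, at which 1 of the 3 values shown sits.

The compounds shown leave open whether the gain follows from the aldehyde itself or from the loss of the long chain, and whether a shorter chain or a simple amine on this carbonyl carbon would behave like either end. They also leave open how an ethyl group on the aromatic carbon of the core would act alongside the aldehyde.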